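The source may report more compounds than this note shows. Statements on the series, on what has been measured and on what is new or still open speak of the compounds shown alone.

Measured so far in an ADME assay on a cell-free system (plasma, Mus musculus) for metabolic stability, read by HPLC, with a stated time of 120 min, tested at 2 uM; a lower number here means that the compound disappears faster, a higher number that the compound lasts longer:

Compound 1 `O=C(NCCCCc1ccccc1)n1nnc2ncccc21`: < 0.0834 h in this assay, a limit of the assay and not a number.
Compound 2 `COc1nc2ccccc2n1C(=O)NCCCCc1ccccc1`: > 2 h in this assay, likewise a limit and not a number.

Where compound 2 stands: of the two values shown, compound 2 sits at the limit of > 2 h in this assay, at which 1 of the 2 values shown sits. Compound 1 sits at the limit of < 0.0834 h in this assay, at which 1 of the 2 values shown sits. Among the compounds with values here, the two compounds differ in more than one place, so no single step between them is counted; all that can be said of the pair is that each value shown is a limit, and the two limits are not the same one.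

Next compound: compound 3 `Nc1nc2ccccc2n1C(=O)NCCCCc1ccccc1`, not yet measured in this assay. It differs from compound 2 in one place, (amino in place of methoxy on an aromatic carbon).

Within the data shown here, no measured step bears on this change, and nothing in the two values shown speaks for it moving the half-life in either direction. The step from compound 2 to compound 3 is therefore expected to be none beyond the usual scatter, a step that the limit leaves unreadable from compound 2 to compound 3. Compound 3 is estimated at 2.5 h in this assay, within a range of 0.8 h to 6 h.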

Compound 3, half-life in the plasma assay: 0.15 h
Compound 3: the middle estimate sits 17-fold (1.22 log units) above what was measured; measured number outside the range, below it.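

Methoxy and amino now prove not to be interchangeable at this position, the aromatic carbon between two ring nitrogen atoms: in the plasma assay the change gives an at least 13-fold lower number from compound 2 to compound 3 (1.12 log units; beyond the scatter), and in a physicochemical assay for metabolic stability, read by HPLC, at pH 4.5, tested at 10 uM (on this read-out lower numbers stand for a shorter-lived compound and higher numbers for a longer-lived compound), it gives an at least 2.7-fold lower number from compound 2 to compound 3 (0.44 log units; beyond the scatter). In the physicochemical assay compound 2 gives > 2 h, a limit of the assay and not a number. In the physicochemical assay compound 3 gives 0.717 h, so this one change, which swaps two heavy atoms for one and adds a hydrogen-bond donor, shortens the half-life in both settings.

From the compounds shown here alone, whether a hydroxy, a methyl or a dimethylamino group at this position would stay with compound 2 or fall with compound 3 remains open, as does the full size of both steps, each of which has a limit on the side of compound 2. Nothing measured here gives a cause for the steps.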